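From dimethylphenyl to furan in a cytotoxicity test

A few compounds are considered here, and "the series" means these few. Any claim that something is new, unique, unknown or untested is made for them only; others in the source may bear on it.

Compound 1 `COC1=C(C)C(=O)/C(=C(O)/C=C/c2ccc(O)cc2)C(=O)C1(C)C`: 3.8 ug/mL
Compound 2 `COC1=C(C)C(=O)/C(=C(O)/C=C/c2c(C)cccc2C)C(=O)C1(C)C`: 3 ug/mL

Both numbers come from a functional assay on HUVEC cells (Homo sapiens) for cytotoxicity; a higher number here means that more compound is needed for the effect, a lower number that less compound is needed. Compound 2 gives 3 ug/mL and compound 1 gives 3.8 ug/mL, so the two cannot be told apart. For the measured compounds named here, the only measured step is a 1.3-fold lower number from compound 1 to compound 2 (0.10 log units; within the scatter), and it lies within the usual scatter of repeated measurements.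

The next compound is compound 3 `COC1=C(C)C(=O)/C(=C(O)/C=C/c2ccco2)C(=O)C1(C)C`, which keeps the shared core and changes one group: furan-2-yl in place of 2,6-dimethylphenyl on a double-bonded chain carbon bound to a double-bonded chain carbon. In words, furan-2-yl comes in place of 2,6-dimethylphenyl on a double-bonded chain carbon bound to a double-bonded chain carbon. Going by the values given here, the one measured step changed the group at this same place, so it is the only guide, and a thin one, since no measured compound carries a furan ring. Among the compounds with values here, with so small a step as the sole evidence, no change beyond the scatter is expected in this assay. The expected step is a 1.2-fold higher number from compound 2 to compound 3 (0.07 log units; within the scatter). For compound 3 the estimated value is 3.5 ug/mL, with an expected range of 1.5 ug/mL to 8 ug/mL.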

Compound 3, concentration for half-maximal effect: 2.4 ug/mL
Compound 3: middle estimate off by 1.5-fold (0.16 log units), on the high side, and the stated range covers the measured number.
By their numbers in this assay, from the lowest: compounds 3, 2 and 1 (each within the scatter of the next).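

In this assay the exchange of 2,6-dimethylphenyl for furan-2-yl gives a 1.3-fold lower number from compound 2 to compound 3 (0.10 log units; within the scatter) and the exchange of 4-hydroxyphenyl for furan-2-yl gives a 1.6-fold lower number from compound 1 to compound 3 (0.20 log units; within the scatter) on the same double-bonded chain carbon. The earlier compounds had shown only six-membered aromatic rings of carbon at this place; now a five-membered aromatic ring with 1 hetero atom and fewer heavy atoms stands there, and all three numbers still cannot be told apart. So far, then, this place has accepted these three rings with no change that can be read in this cell test, and nothing measured here explains that outcome.

From the compounds shown here alone, what remains open is whether any group at this place can move the number beyond the scatter, for instance an amine, a carboxylic acid or a longer chain in place of an aromatic ring. All three compounds also share the same core, so they say nothing about how much a change elsewhere in the molecule would matter in this test.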